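Urea amine swap on the triarylethylene amine series

A few compounds are considered here, and "the series" means these few. Any claim that something is new, unique, unknown or untested is made for them only; others in the source may bear on it.

Compound 1 `COc1ccc(/C(=C(/CCN)c2ccccc2)c2ccccc2)cc1` carries a free primary amine, and in a functional assay on MDA-MB-231 cells (Homo sapiens) for cytotoxicity, read by MTT assay, with a stated time of 72 h (on this read-out higher numbers stand for weaker inhibition and lower numbers for stronger inhibition), compound 1 gives 11400 nM. Among the measured compounds shown here, compound 2 `COc1ccc(/C(=C(/CCNC(=O)N2CCOCC2)c2ccccc2)c2ccccc2)cc1` has that amine capped as a urea; in this assay compound 2 gives 42800 nM, the highest of the two numbers known so far. For the measured compounds named here, the only measured step, a 3.8-fold higher number from compound 1 to compound 2 (0.57 log units; beyond the scatter), shows the cap itself costing potency. Compound 3 `CCN(CC)C(=O)NCC/C(=C(\c1ccccc1)c1ccc(OC)cc1)c1ccccc1` keeps the urea and alters only its amine portion: diethylamino in place of morpholin-4-yl on a carbonyl carbon. Going by the values given here, no measured step covers a swap of this kind; the step from compound 1 to compound 2 speaks to adding the urea, not to varying the group on it, and fixes no direction here. With the urea retained and the counted difference small, no shift beyond the scatter is expected for compound 3, and a 1.1-fold lower number from compound 2 to compound 3 (0.03 log units; within the scatter) is the estimated step. Compound 3 is expected to give 40000 nM, within 15000 nM to 110000 nM.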

Compound 3, half-maximal inhibitory concentration: 40700 nM
Beside the measured number, compound 3's estimate is 1.0-fold (0.01 log units) below it; the range from low to high includes it.
By their numbers in this assay, from the lowest: compound 1; then compounds 3 and 2 (each within the scatter of the next).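

In this assay, diethylamino in place of morpholin-4-yl on a carbonyl carbon gives a 1.1-fold lower number from compound 2 to compound 3 (0.02 log units; within the scatter), so removing the ring and its oxygen from the urea's amine portion produces no change beyond the scatter in this pair. The cost of capping the free amine now appears with a second urea, a 3.6-fold higher number from compound 1 to compound 3 (0.55 log units; beyond the scatter), alongside a 3.8-fold higher number from compound 1 to compound 2 (0.57 log units; beyond the scatter); both steps lie beyond the scatter, and in these two compounds the loss does not depend on which of the two amine portions is present. No supporting data bear on the reason for either result.

Still open, as far as these compounds go, is whether an amine portion such as piperazin-1-yl or one bearing a carboxylic acid would also leave the number unchanged. From the compounds shown here alone, it is equally open whether a simple acetyl amide on the amine nitrogen, or a longer chain leading to it, would carry the same cost as the ureas.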